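Trimming a Side Chain in an Oral Tail Flick Test

The compounds below may be only part of what the source reports. "The series", "measured", "known", "first", "only" and "open" are said of these compounds alone.

Measured so far, in a functional assay on the whole organism (Tail, strain ICR) with Mus musculus as the target, in the tail flick test, with a stated time of 150 min, at a dose of 25 umol/kg by the oral route; on this read-out lower numbers stand for a weaker effect and higher numbers for a stronger effect at the one dose given:
compound 1 `NC(=O)CC[C@H](NC(=O)CN(c1ncnc2c1ncn2C1CCCCO1)C1CC1)C(=O)OCc1ccccc1` gives 10.7%
compound 2 `CC(C)[C@H](NC(=O)CN(c1nc(Cl)nc2[nH]cnc12)C1CC1)C(=O)OCc1ccccc1` gives 17.9%

Compound 1 and compound 2 sit within the usual scatter of each other, so neither stands apart; compound 1 serves here as the starting point. Compound 3 `O=C(CN(c1ncnc2c1ncn2C1CCCCO1)C1CC1)NCC(=O)OCc1ccccc1` differs from compound 1 by hydrogen in place of 2-carbamoylethyl on a saturated chain carbon bound to an amide-type nitrogen and a carbonyl carbon. Among the compounds with values here, no measured pair shows a change of this kind, so there is nothing to suggest a shift beyond the scatter; the step is expected to be small, a number 1.3 percentage points higher from compound 1 to compound 3 (within the scatter). Compound 3 is therefore estimated at 12%, most likely between 2% and 28%.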

Compound 3, a percentage reported as activity, at one dose (the size of the read-out at that dose, not a potency): 7.26%
Compound 3: the middle estimate sits 4.7 percentage points above what was measured; the range from low to high includes it.
By their numbers in this assay, from the lowest: compounds 3, 1 and 2 (each within the scatter of the next, the first and the last beyond it).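

Replacing 2-carbamoylethyl with hydrogen on this saturated chain carbon gives, in this assay, a number 3.4 percentage points lower from compound 1 to compound 3 (within the scatter). At this one dose and time, the whole side chain can therefore go without a shift that stands clear of the scatter. Nothing available explains this result.

Going by these compounds, what a methyl group, a carboxylic acid or an amine on a longer chain would give at this carbon stays open. So does whether the same step would look alike at other doses.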